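The compounds below may be only part of what the source reports. "The series", "measured", "known", "first", "only" and "open" are said of these compounds alone.

Series notes, step from compound 3 to compound 4.

Three compounds carry numbers in a functional assay on L1210 cells (Mus musculus) for cytotoxicity; on this read-out higher numbers stand for weaker inhibition and lower numbers for stronger inhibition. Compound 1 `O=C(/C=C/C(=O)N1C/C(=C\c2ccccc2)C(=O)/C(=C/c2ccccc2)C1)Nc1ccc(Cl)c(Cl)c1` gives 7500 nM. Compound 2 `Cc1ccc(NC(=O)/C=C/C(=O)N2C/C(=C\c3ccc([N+](=O)[O-])cc3)C(=O)/C(=C/c3ccc([N+](=O)[O-])cc3)C2)cc1C` gives 4900 nM. Compound 3 `Cc1ccc(NC(=O)/C=C/C(=O)N2C/C(=C\c3ccc([N+](=O)[O-])cc3)C(=O)/C(=C/c3ccc([N+](=O)[O-])cc3)C2)cc1` gives 4400 nM, the lowest of the three numbers; compound 2 is nearest and compound 1 furthest, but both gaps are within the scatter, so no order among the three can be read from this assay. Going by the values given here, the one step between neighbours that differ in a single place, hydrogen in place of methyl on an aromatic carbon, reads a 1.1-fold lower number from compound 2 to compound 3 (0.05 log units; within the scatter).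

Compound 4 `COc1ccc(NC(=O)/C=C/C(=O)N2C/C(=C\c3ccc([N+](=O)[O-])cc3)C(=O)/C(=C/c3ccc([N+](=O)[O-])cc3)C2)cc1` differs from compound 3 by methoxy in place of methyl on an aromatic carbon. Among the compounds with values here, the only measured step that bears on it is the change at the same aromatic carbon from compound 2 to compound 3, which stayed within the scatter. Within the data shown here, no measured pair shows methoxy entering anywhere. On that basis compound 4 is expected to sit close to compound 3 in this assay, with a step of no change at the digits printed from compound 3 to compound 4 (within the scatter), none beyond the scatter. The estimate for compound 4 is 4400 nM, within the range 2000 nM to 9500 nM.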

Compound 4, half-maximal inhibitory concentration: 2900 nM
Compound 4: middle estimate off by 1.5-fold (0.18 log units), on the high side; measured number inside the range.
By their numbers in this assay, from the lowest: compounds 4, 3, 2 and 1 (each within the scatter of the next, the first and the last beyond it).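

In this assay, going by these compounds alone, this is the first reading of methoxy at this aromatic carbon, para to a large group, and the swap from methyl gives a 1.5-fold lower number from compound 3 to compound 4 (0.18 log units; within the scatter). Exchanging the whole 3,4-dimethylphenyl on the amide-type nitrogen for 4-methoxyphenyl gives a 1.7-fold lower number from compound 2 to compound 4 (0.23 log units; within the scatter), so an oxygen-linked group and a hydrogen-bond acceptor can enter here without a step beyond the scatter, at least while the rest of the molecule stays as in compounds 2, 3 and 4. Nothing available explains this flat response.

Going by these compounds, whether an amine, a hydroxyl or a carboxylic acid at this carbon would produce a step beyond the scatter remains open. Compound 1 differs from compounds 2, 3 and 4 in more than one place, so steps to it cannot be read.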